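Cytotoxicity notes: butoxy to phenyl on the shared core

The compounds below may be only part of what the source reports. "The series", "measured", "known", "first", "only" and "open" are said of these compounds alone.

Of the compounds shown here, three have been tested in an ADME assay on U2OS cells (Homo sapiens) for cytotoxicity; a lower number here means that less compound is tolerated, a higher number that more compound is tolerated. Compound 1 `CC(C)(C)c1ccc(C(=O)N/N=C/c2ccc([N+](=O)[O-])o2)cc1` gives only a limit there, > 200000 nM. Compound 2 `CCCCc1ccc(C(=O)N/N=C/c2ccc([N+](=O)[O-])o2)cc1` gives 19600 nM in this assay, and compound 3 `CCCCOc1ccc(C(=O)N/N=C/c2ccc([N+](=O)[O-])o2)cc1` gives 46600 nM. Compound 3 therefore holds the highest of the two numbers; the step of a 2.4-fold higher number from compound 2 to compound 3 (0.38 log units; beyond the scatter) sets it apart from compound 2, and the steps of an at least 10-fold lower number from compound 1 to compound 2 (1.00 log units; beyond the scatter) and an at least 4.2-fold lower number from compound 1 to compound 3 (0.63 log units; beyond the scatter) both run downward from the limit.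

Compound 4 `O=C(N/N=C/c1ccc([N+](=O)[O-])o1)c1ccc(-c2ccccc2)cc1` differs from compound 3 in one place: phenyl in place of butoxy on an aromatic carbon. For the measured compounds named here, no measured step exchanges an alkyl or alkoxy group for an aromatic ring, so the nearest guide is the modest step of a 2.4-fold higher number from compound 2 to compound 3 (0.38 log units; beyond the scatter) between the two four-carbon chains, with the larger steps from tert-butyl showing that this position can move the number more. A step of modest size is expected in this assay, direction uncertain, a lower number judged somewhat more likely than a higher one. For compound 4 the expected value in this assay is 30000 nM, within 8000 nM to 120000 nM. The step this estimate implies is a 1.6-fold lower number from compound 3 to compound 4 (0.19 log units; within the scatter).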

Compound 4, half-maximal cytotoxic concentration: 109000 nM
Beside the measured number, compound 4's estimate is 3.6-fold (0.56 log units) below it; measured number inside the range.
By their numbers in this assay, from the lowest: compound 2; then compound 3; then compound 4. At a limit, above all of these: compound 1.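

In this assay, phenyl on this aromatic carbon, para to a large group, gives the highest number among compound 2, compound 3 and compound 4, with a 2.3-fold higher number from compound 3 to compound 4 (0.37 log units; beyond the scatter), a 5.6-fold higher number from compound 2 to compound 4 (0.75 log units; beyond the scatter) and an at least 1.8-fold lower number from compound 1 to compound 4 (0.26 log units; that floor lies within the scatter). For the compounds shown here, the earlier compounds carried only four-carbon chains or tert-butyl here, so this is the first sign that a six-membered aromatic ring of carbon only can stand at this position with more compound tolerated than with either straight chain; the count of hydrogen-bond acceptors in the group does not order these numbers, as compound 2 and compound 4 both have none in it yet lie at opposite ends of the three. Compound 1 gives only a limit, and its step to the new entry is only a floor because of that limit: the limit of > 200000 nM in this assay, at which 1 of the 4 values shown sits.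

Going by these compounds, whether the higher number belongs to the aromatic ring itself or to any ring stays open, and a cyclohexyl group at the same position would separate the two. Equally open, on these data alone, is whether a pyridyl ring, or a phenyl carrying an amine or a carboxylic acid, would keep the number where phenyl puts it.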